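Shrinking the amine on the core: compound 1 to compound 4

A few compounds are considered here, and "the series" means these few. Any claim that something is new, unique, unknown or untested is made for them only; others in the source may bear on it.

Compound 1 `O=C(CCc1ccc(C(F)(F)F)cc1)Nc1ccc2nc(N3CCC(c4ccccc4)C3)ccc2c1` stands at the top of the three numbers in a functional assay on HEK293 cells for activation of melanin-concentrating hormone receptor 1 (Rattus norvegicus), read by inositol phosphate accumulation (a higher number here means that more compound is needed for the effect, a lower number that less compound is needed), where compound 1 gives 1770 nM. The nearest number belongs to compound 2 `O=C(CCc1ccc(C(F)(F)F)cc1)Nc1ccc2nc(N3CC4CC3CN4)ccc2c1`, which in this assay gives 490 nM; the furthest to compound 3 `O=C(CCCCCCCCCCCCc1ccc(C(F)(F)F)cc1)Nc1ccc2nc([N+]34CCC(CC3)CC4)ccc2c1`, which gives 25 nM, but compound 3 differs from compound 1 in more than one place, so its value alone does not isolate the amine.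

Compound 4 `O=C(CCc1ccc(C(F)(F)F)cc1)Nc1ccc2nc(N3CCC3)ccc2c1` carries the change (azetidin-1-yl in place of 3-phenylpyrrolidin-1-yl on an aromatic carbon). For the measured compounds named here, the one measured step that bears on it is a 3.6-fold lower number from compound 1 to compound 2 (0.56 log units; beyond the scatter), where a smaller amine without the phenyl ring also replaced 3-phenylpyrrolidin-1-yl. Azetidin-1-yl is smaller still and likewise lacks the six-membered aromatic ring of carbon only, so a step of similar size and direction is expected, though with one step as the only guide the range is wide.

Compound 4 is expected to give 800 nM in this assay, between 250 nM and 2600 nM, which would mean a 2.2-fold lower number from compound 1 to compound 4 (0.34 log units; beyond the scatter).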

Compound 4, half-maximal effective concentration: 56 nM
Estimate against measurement, compound 4: 14-fold (1.15 log units) above; measured number outside the range, below it.
By their numbers in this assay, from the lowest: compound 3; then compound 4; then compound 2; then compound 1.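

On the aromatic carbon next to the ring nitrogen, azetidin-1-yl in place of 3-phenylpyrrolidin-1-yl gives in this assay a 32-fold lower number from compound 1 to compound 4 (1.50 log units; beyond the scatter), a much larger step than the earlier one to the bridged diamine. Azetidin-1-yl also goes beyond that diamine, with an 8.8-fold lower number from compound 2 to compound 4 (0.94 log units; beyond the scatter), so among compound 1, compound 2 and compound 4, which differ only in this amine, the number falls as the amine gets smaller, and none of the three goes against this. No measurement available here accounts for the size of these steps.

Unsubstituted pyrrolidin-1-yl would separate the loss of the phenyl ring from the change in ring size, and the compounds shown cannot make that separation. From the compounds shown here alone, whether the trend continues to an open-chain amine such as dimethylamino also remains open.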